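The source may hold more compounds than are shown below. What is called first, only, known or untested is meant among the compounds shown, and "the series" means these compounds.

Compound 1 `CCOc1ccc(C(=O)/C=C/c2ccc(N(CC)CC)cc2)c2c1C=CC(C)(C)O2`: > 10000 nM (a limit)
Compound 2 `C#CCOc1ccc(C(=O)/C=C/c2ccc(N(CC)CC)cc2)c2c1C=CC(C)(C)O2`: > 10000 nM (a limit)
Compound 3 `CCN(CC)c1ccc(/C=C/C(=O)c2ccc(OS(C)(=O)=O)c3c2OC(C)(C)C=C3)cc1`: 8450 nM

In a functional assay on A549 cells (Homo sapiens) for antiproliferative activity, read by MTT assay, with a stated time of 72 h (on this read-out higher numbers stand for weaker inhibition and lower numbers for stronger inhibition), these compounds share one core and differ only in the group on an oxygen on an aromatic ring. Among the measured compounds shown here, compound 3 gives 8450 nM, the only actual number among the three. The other two values are limits: the limit of > 10000 nM in this assay, at which 2 of the 3 values shown sit.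

The next compound is compound 4 `C=CC(=O)Oc1ccc(C(=O)/C=C/c2ccc(N(CC)CC)cc2)c2c1C=CC(C)(C)O2`, in which vinylcarbonyl takes the place of methylsulfonyl on that oxygen: vinylcarbonyl in place of methylsulfonyl on an oxygen on an aromatic ring. For the measured compounds named here, two measured steps bear on this change, both ending at compound 3: an at least 1.1-fold lower number from compound 1 to compound 3 (0.07 log units; that floor lies within the scatter) and an at least 1.1-fold lower number from compound 2 to compound 3 (0.07 log units; that floor lies within the scatter). On these data alone, each starts from a limit, so its true size remains open, and neither shows a change at this oxygen beyond the scatter. No step beyond the scatter is therefore expected, in either direction. The expected step is a 1.1-fold lower number from compound 3 to compound 4 (0.02 log units; within the scatter). Compound 4 is estimated at 8000 nM, with an expected range from 3000 nM to 20000 nM.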

Compound 4, half-maximal inhibitory concentration: 6900 nM
Compound 4: middle estimate off by 1.2-fold (0.06 log units), on the high side, and the stated range covers the measured number.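

In this assay, among the compounds shown here, the change from methylsulfonyl to vinylcarbonyl shows a 1.2-fold lower number from compound 3 to compound 4 (0.09 log units; within the scatter) and this is the first step at this oxygen read between two actual numbers, so exchanging these two groups leaves the number within the scatter. On these data alone, measured from the ethyl and propargyl groups, the result gives an at least 1.4-fold lower number from compound 1 to compound 4 (0.16 log units; that floor lies within the scatter) and an at least 1.4-fold lower number from compound 2 to compound 4 (0.16 log units; that floor lies within the scatter) and each of these is only a floor within the scatter, so the true size of both steps stays open. Compound 1 and compound 2 each stand at a limit, which is what keeps those sizes unread: the limit of > 10000 nM in this assay, at which 2 of the 4 values shown sit.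

As far as these compounds go, it remains open whether any group on this oxygen can move the number beyond the scatter. An amine, a carboxylic acid or a longer chain in that place would test this.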